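The source may report more compounds than this note shows. Statements on the series, on what has been measured and on what is new or still open speak of the compounds shown alone.

Measured so far in this series:
compound 1 `COc1cc(C2Oc3cc([C@H]4Oc5cc(O)cc(O)c5C(=O)[C@@H]4O)ccc3OC2COC(=O)c2cc(N)cc([N+](=O)[O-])c2)ccc1O` — > 300000 nM
compound 2 `COc1cc(C2Oc3cc([C@H]4Oc5cc(O)cc(O)c5C(=O)[C@@H]4O)ccc3OC2COC(=O)/C=C/c2ccc(C)cc2)ccc1O` — 136000 nM

In a functional assay, read by spectrophotometry, with a stated time of 30 min (a higher number here means that more compound is needed for the effect, a lower number that less compound is needed), compound 2 gives 136000 nM, the only number shown for the series. The value of compound 1 is a limit of the assay, not a number (the limit of > 300000 nM in this assay, at which 1 of the 2 values shown sits). Within the data shown here, the one measured step, an at least 2.2-fold lower number from compound 1 to compound 2 (0.34 log units; beyond the scatter), is itself bounded by that limit.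

Compound 3 `COc1cc(C2Oc3cc([C@H]4Oc5cc(O)cc(O)c5C(=O)[C@@H]4O)ccc3OC2COC(=O)/C=C/c2ccc(Cl)cc2)ccc1O` differs from compound 2 by chloro in place of methyl on an aromatic carbon. The measured step concerns an exchange of the whole aryl group and does not bear on this change. No step beyond the scatter is expected: compound 3 is estimated at 120000 nM, between 50000 nM and 300000 nM. The expected step is a 1.1-fold lower number from compound 2 to compound 3 (0.05 log units; within the scatter).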

Compound 3, half-maximal effective concentration: 87900 nM
Beside the measured number, compound 3's estimate is 1.4-fold (0.14 log units) above it; measured number inside the range.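

In this assay, chloro in place of methyl on the aromatic carbon gives a 1.5-fold lower number from compound 2 to compound 3 (0.19 log units; within the scatter), so this position accepts the exchange with no change that can be read. The 2-(4-chlorophenyl)ethenyl group in place of 3-amino-5-nitrophenyl gives an at least 3.4-fold lower number from compound 1 to compound 3 (0.53 log units; beyond the scatter). The value of compound 1 is a limit and not a number, so this step is bounded: the limit of > 300000 nM in this assay, at which 1 of the 3 values shown sits.

On these data alone, it remains open whether an amine or a carboxylic acid on this aromatic carbon would move the number beyond the scatter. As far as these compounds go, the role of the ethenyl part also remains open, for which a saturated ethyl chain would be the comparison.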